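The compounds below may be only part of what the source reports. "The series", "measured", "known", "first", "only" and "open" are said of these compounds alone.

Measured compounds in a functional assay on DLD-1 cells (Homo sapiens) for cytotoxicity, read by colorimetric assay and MTT assay, with a stated time of 3 days, tested at 1 uM; a higher number here means a weaker effect of the compound at the concentration tested, a lower number a stronger effect:
- compound 1, `Cc1ccccc1-n1cc(-c2ccccc2)c(-c2ccc3c(c2)NC(=O)CO3)n1`: 92.2%
- compound 2, `O=C1COc2ccc(-c3nn(-c4cc(Cl)cc(Cl)c4)cc3-c3ccccc3)cc2N1`: 90.3%

Among the compounds with values here, compound 2 stands lowest of the two numbers in this assay, but its only neighbour is compound 1, and the step of a number 1.9 percentage points lower from compound 1 to compound 2 (within the scatter) is within the scatter, so the two compounds are not separated by this read-out. Both show only weak cytotoxicity at the concentration tested.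

Compound 3, `O=C1COc2ccc(-c3nn(-c4ccccc4)cc3-c3ccccc3)cc2N1`, is not yet measured in this assay. It differs from compound 2 by phenyl in place of 3,5-dichlorophenyl on an aromatic nitrogen. Within the data shown here, the one measured step that bears on this position, a number 1.9 percentage points lower from compound 1 to compound 2 (within the scatter), also exchanged one aryl group for another on the same aromatic nitrogen and stayed within the scatter. Nothing in the data suggests that this position moves the read-out, so no step beyond the scatter is expected for the change to phenyl, in either direction. Compound 3 is therefore expected to give about 91% in this assay, with a plausible range from 80% to 100%. The step this estimate implies, a number 0.7 percentage points higher from compound 2 to compound 3 (within the scatter), is expected to lie within the scatter.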

Compound 3, a percentage reported as activity, at one concentration (the size of the read-out at that concentration, not a potency): 77%
Compound 3: the middle estimate sits 14 percentage points above what was measured; the whole stated range lies above it.
By their numbers in this assay, from the lowest: compound 3; then compounds 2 and 1 (each within the scatter of the next).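

In this assay phenyl in place of 3,5-dichlorophenyl on the aromatic nitrogen gives a number 13.3 percentage points lower from compound 2 to compound 3 (beyond the scatter) and removal of the methyl from the 2-methylphenyl group gives a number 15.2 percentage points lower from compound 1 to compound 3 (beyond the scatter) on the same nitrogen. This position therefore does move the read-out, which the exchange between the two substituted aryl groups could not show, as those two compounds stand within the scatter of each other; among these three compounds, both the two chlorines and the methyl go with a weaker effect at the concentration tested than the unsubstituted phenyl. No available measurement accounts for this difference.

The compounds shown leave open whether a single chlorine or a methoxy group on the phenyl ring would also weaken the effect, and whether an aminomethyl group, a carboxylic acid or a pyridine ring in place of the phenyl would carry the effect further in either direction. A read-out at one concentration also leaves open how these differences in effect would appear at other concentrations.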